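Amide variation on the shared core: toward compound 4

The source may report more compounds than this note shows. Statements on the series, on what has been measured and on what is new or still open speak of the compounds shown alone.

Measured so far in an assay on microsomes from liver for inhibition of 3-hydroxy-3-methylglutaryl-coenzyme A reductase (Rattus norvegicus); on this read-out lower numbers stand for stronger inhibition and higher numbers for weaker inhibition:
compound 1 `CC(C)c1c(C(=O)N2CCCC2c2ccccc2)nn(-c2ccc(F)cc2)c1OC[C@@H](O)C[C@@H](O)CC(=O)O`: 14 nM
compound 2 `Cc1cccc(CNC(=O)c2nn(-c3ccc(F)cc3)c(OC[C@@H](O)C[C@@H](O)CC(=O)O)c2C(C)C)c1`: 4.9 nM
compound 3 `CC(C)c1c(C(=O)NCc2ccccc2Cl)nn(-c2ccc(F)cc2)c1OC[C@@H](O)C[C@@H](O)CC(=O)O`: 9.5 nM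

Compound 2 gives the lowest number of the three in this assay, but compound 3 sits within the scatter of it; only compound 1 stands apart, since a 2.9-fold lower number from compound 1 to compound 2 (0.46 log units; beyond the scatter). The step of a 1.5-fold lower number from compound 1 to compound 3 (0.17 log units; within the scatter) is within the scatter, as is a 1.9-fold higher number from compound 2 to compound 3 (0.29 log units; within the scatter), so the substitution pattern on the benzyl ring has not yet shown an effect that can be read.

Compound 4 `CC(C)c1c(C(=O)N(C)Cc2ccc(F)c(F)c2)nn(-c2ccc(F)cc2)c1OC[C@@H](O)C[C@@H](O)CC(=O)O` differs from compound 2 in one place: (3,4-difluorobenzyl)(methyl)amino in place of (3-methylbenzyl)amino on a carbonyl carbon. Two things change at once: the amide nitrogen loses its hydrogen-bond donor and gains a methyl group, and the ring substituents change. Among the compounds with values here, the only measured step touching the amide nitrogen is a 2.9-fold lower number from compound 1 to compound 2 (0.46 log units; beyond the scatter), where the one tertiary amide of the set, compound 1, gave the highest number; the ring changes in a 1.9-fold higher number from compound 2 to compound 3 (0.29 log units; within the scatter) stayed within the scatter. Compound 4 is therefore expected to come in with a somewhat higher number than compound 2, of the order of a 2.0-fold higher number from compound 2 to compound 4 (0.31 log units; beyond the scatter), though a result within the scatter cannot be ruled out. Compound 4 is estimated at 10 nM, with a range from 4 nM to 25 nM.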

Compound 4, half-maximal inhibitory concentration: 5.7 nM
Beside the measured number, compound 4's estimate is 1.8-fold (0.24 log units) above it; the range from low to high includes it.
By their numbers in this assay, from the lowest: compounds 2, 4, 3 and 1 (each within the scatter of the next, the first and the last beyond it).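

In this assay, a tertiary amide without the amide hydrogen can match the secondary amides at this carbonyl carbon: a 1.2-fold higher number from compound 2 to compound 4 (0.07 log units; within the scatter) and a 1.7-fold lower number from compound 3 to compound 4 (0.22 log units; within the scatter) both leave the numbers within the scatter, so the combined change of the amide hydrogen for a methyl group and of the ring substituents has no effect that can be read. The tertiary amides also no longer fall together, as a 2.5-fold lower number from compound 1 to compound 4 (0.39 log units; beyond the scatter) separates the two, so the higher number of compound 1 goes with 2-phenylpyrrolidin-1-yl in particular and not with the missing amide hydrogen as such. No supporting data bear on why this change leaves the number so little altered.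

The methyl group on the amide nitrogen and the two ring fluorines changed together, so small opposing contributions cannot be excluded, and (3-methylbenzyl)(methyl)amino or (3,4-difluorobenzyl)amino would separate them. Also open, on these data alone, is how this position responds to an amine group that carries no aromatic ring, such as morpholin-4-yl, or to a longer chain between nitrogen and ring, such as 2-phenylethylamino.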